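The compounds below may be only part of what the source reports. "The series", "measured", "known", "first", "only" and "open" are said of these compounds alone.

Compound 1, `COc1ccc(N2CCN(CC(=O)N3CCN(c4nnc(-c5ccccc5)c(-c5ccccc5)n4)CC3)CC2)cc1`, in an ADME assay on NIH3T3 cells (Mus musculus) for cytotoxicity, read by MTT assay, with a stated time of 24 h; a lower number here means a stronger inhibitor, a higher number a weaker inhibitor: > 910000 nM, a limit of the assay rather than a number.
Compound 2, `Cc1ccc(-c2nnc(N3CCN(C(=O)CN4CCN(c5ccccc5)CC4)CC3)nc2-c2ccc(C)cc2)cc1`, in this assay: > 914000 nM, again a limit rather than a number.

Compound 2 therefore stands at the top of what the measurement can report: its value is the limit of > 914000 nM in this assay, at which 1 of the 2 values shown sits, with no inhibition seen within the tested range. Compound 1 sits at a similar ceiling, shown by the limit of > 910000 nM in this assay, at which 1 of the 2 values shown sits. Among the measured compounds shown here, neither compound gives a real number, so no measured step between them can be described.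

Compound 3, `COc1ccccc1N1CCN(CC(=O)N2CCN(c3nnc(-c4ccc(C)cc4)c(-c4ccc(C)cc4)n3)CC2)CC1`, has not yet been measured. It differs from compound 2 by methoxy in place of hydrogen on an aromatic carbon. For the measured compounds named here, no measured pair shows what this change does here. Compound 3 is expected to give 1000000 nM, within a range from 400000 nM to 2500000 nM, most likely again reported only as a limit. The expected step that the limit leaves unreadable from compound 2 to compound 3 amounts to none beyond the scatter.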

Compound 3, half-maximal inhibitory concentration: 133000 nM
For compound 3 the middle estimate is 7.5-fold (0.88 log units) above the measured one; measured number outside the range, below it.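

In this assay, the change from phenyl to 2-methoxyphenyl, on an aromatic carbon ortho to a large group, gives an at least 6.8-fold lower number from compound 2 to compound 3 (0.83 log units; beyond the scatter). Among the compounds shown here, this is the first sign that this place on the molecule can shift the read-out at all, since compound 3 gives a real number where the earlier compounds gave only limits. The true size of the step remains unknown, and the printed figure is only its smallest possible size, since the starting point is a limit and not a number: the limit of > 914000 nM in this assay, at which 1 of the 3 values shown sits.

The compounds shown leave open whether fluorine, a hydroxyl or an amine at this same place would also lower the number, or whether this effect is particular to methoxy. They also leave open whether the same change would give a similar step on a different core.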